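A few compounds are considered here, and "the series" means these few. Any claim that something is new, unique, unknown or untested is made for them only; others in the source may bear on it.

Values in a functional assay on HeLa cells (Homo sapiens) for cytotoxicity, read by MTT assay, with a stated time of 48 h (on this read-out lower numbers stand for stronger inhibition and higher numbers for weaker inhibition), for the measured compounds

- Compound 1 `Cc1ccc(C)c(/C=C/[C@](C)(O)CC[C@@H]2[C@@]3(C)CCCC(C)(C)[C@@H]3CC[C@@]2(C)O)c1` gives 3380 nM
- Compound 2 `COc1cccc(OC)c1/C=C/[C@](C)(O)CC[C@@H]1[C@@]2(C)CCCC(C)(C)[C@@H]2CC[C@@]1(C)O` gives 48200 nM
- Compound 3 `Cc1cccc(/C=C/[C@](C)(O)CC[C@@H]2[C@@]3(C)CCCC(C)(C)[C@@H]3CC[C@@]2(C)O)c1C` gives 3700 nM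

Compound 3 stands level with compound 1 (a 1.1-fold higher number from compound 1 to compound 3 (0.04 log units; within the scatter)) and far under compound 2 (a 13-fold lower number from compound 2 to compound 3 (1.11 log units; beyond the scatter)). Going on to compound 4 `CC1(C)CCC[C@]2(C)[C@@H](CC[C@@](C)(O)/C=C/c3ccc(Cl)nc3)[C@](C)(O)CC[C@@H]12` swaps only the aromatic group (6-chloropyridin-3-yl in place of 2,3-dimethylphenyl on a double-bonded chain carbon bound to a double-bonded chain carbon) on a double-bonded chain carbon bound to a double-bonded chain carbon. All measured steps are swaps at this same place. One stayed within the scatter, and the two involving compound 2 were large (a 14-fold higher number from compound 1 to compound 2 (1.15 log units; beyond the scatter)). Within the data shown here, no measured compound carries a pyridine ring or chlorine, so these steps are only a loose guide. In this assay a moderate rise in the number is expected, smaller than those large steps. The expected change is a 1.9-fold higher number from compound 3 to compound 4 (0.28 log units; within the scatter) by this estimate. Compound 4 is estimated at 7000 nM with an expected range from 2000 nM to 25000 nM in this measurement.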

Compound 4, half-maximal inhibitory concentration: 3680 nM
Compound 4: middle estimate off by 1.9-fold (0.28 log units), on the high side; low and high end bracket the measured number.
By their numbers in this assay, from the lowest: compounds 1, 4 and 3 (each within the scatter of the next); then compound 2.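

In this assay the swap to 6-chloropyridin-3-yl gives a 1.0-fold lower number from compound 3 to compound 4 (0.00 log units; within the scatter) and a 1.1-fold higher number from compound 1 to compound 4 (0.04 log units; within the scatter) and both lie within the scatter, so at this position a ring with a hetero atom can match the two dimethylphenyl rings. The large 13-fold lower number from compound 2 to compound 4 (1.12 log units; beyond the scatter) keeps compound 2 apart and shows that a hetero atom in the ring does not by itself bring a number as high as that of compound 2. No outside evidence explains these results.

The compounds shown leave open how this position responds to a ring carrying an amine or a carboxylic acid. They also leave open what a single methoxy group on the phenyl ring would do.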